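The compounds below may be only part of what the source reports. "The series", "measured", "known", "first", "only" and "open" are said of these compounds alone.

Three compounds of this series have been run in a functional assay on A549 cells (Homo sapiens) for antiproliferative activity, read by MTT assay, with a stated time of 72 h; on this read-out lower numbers stand for stronger inhibition and higher numbers for weaker inhibition. Compound 1 `CCCSc1nc(Cl)c2c(n1)N(Cc1ccccc1)C(C(=O)N1CCN(C(=O)OC(C)(C)C)CC1)N2` gives 29000 nM, compound 2 `CCCSc1nc(Cl)c2c(n1)N(Cc1cccs1)C(C(=O)N1CCN(C)CC1)N2` gives 6420 nM, and compound 3 `CCCSc1nc(Cl)c2c(n1)N(Cc1ccccc1)C(C(=O)NCCC1=CCc3ccccc31)N2` gives 48800 nM. Compound 3 holds the highest of the three numbers; its gap to compound 1 lies within the usual scatter, whereas its gap to compound 2 is beyond the scatter, so only compound 2 stands apart from compound 3.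

Compound 4 `CCCSc1nc(Cl)c2c(n1)N(Cc1ccccc1)C(C(=O)NCC(C)C)N2` has not yet been measured in this assay. It differs from compound 3 by a group of 3 heavy atoms (3 carbon; no ring) in place of a group of 10 heavy atoms (10 carbon; one five-membered non-aromatic ring of carbon only, one six-membered aromatic ring of carbon only), on a saturated chain carbon bound to an amide-type nitrogen. Among the compounds with values here, no pair of measured compounds shows this change, and none of the three carries a comparable small amide substituent, so there is no direct precedent.

All three measured values sit in a weak region, so compound 4 is expected to remain there. The expected step is a 1.6-fold lower number from compound 3 to compound 4 (0.21 log units; within the scatter), which is no change beyond the scatter. Compound 4 is thus estimated at 30000 nM in this assay, with a range from 8000 nM to 100000 nM.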

Compound 4, half-maximal inhibitory concentration: 48200 nM
Compound 4: the middle estimate sits 1.6-fold (0.21 log units) below what was measured; the measured number falls inside the stated range.
By their numbers in this assay, from the lowest: compound 2; then compounds 1, 4 and 3 (each within the scatter of the next).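

Within the data shown here, the first single-place step replaces the ring-bearing group of 10 heavy atoms with isopropyl, on a saturated chain carbon bound to an amide-type nitrogen, and gives a 1.0-fold lower number from compound 3 to compound 4 (0.01 log units; within the scatter) in this assay. For this pair, then, the five-membered ring, the six-membered aromatic ring and the double bond outside the aromatic ring can all go without a shift beyond the scatter. No available measurement accounts for the two groups reading alike.

An amine, a carboxylic acid or a longer chain on the same carbon would show whether any group here can move the number beyond the scatter. The separate standing of compound 2 also remains unassigned: it differs from compounds 1, 3 and 4 in more than one place.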